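This account rests on a few compounds, and the source may have more. Where it says the series, first, only, none or still open, it means among the compounds named here.

Measured to date:
- compound 1 `COc1cc2c(cc1N1C[C@@H](C)N(C)[C@@H](C)C1)N(S(=O)(=O)c1ccc3ccccc3c1)CC2`: 0.8
- compound 2 `COc1cc2c(cc1N1C[C@@H](C)N[C@@H](C)C1)N(S(=O)(=O)Cc1cccc(I)c1)CC2`: 0.8
- compound 3 `COc1cc2c(cc1N1C[C@@H](C)N[C@@H](C)C1)N(S(=O)(=O)c1cccc(-c3ccccn3)c1)CC2`: 0.9

The three measured compounds share one core and differ only in the group on the sulfonyl sulfur. In a functional assay with growth hormone secretagogue receptor type 1 (Homo sapiens) as the target (on this read-out lower numbers stand for smaller maximal responses and higher numbers for larger maximal responses), compound 2 gives 0.8, level with compound 1 at the digits shown, and its gap to compound 3 lies within the usual scatter of this assay. All three readings therefore sit in one narrow band, and no ordering among them can be claimed.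

Compound 4 `COc1cc2c(cc1N1C[C@@H](C)N[C@@H](C)C1)N(S(=O)(=O)c1ccc(-c3ccccn3)s1)CC2` has not yet been measured. Relative to compound 2 the change is 5-(pyridin-2-yl)thiophen-2-yl in place of 3-iodobenzyl on a sulfonyl sulfur. Compound 3 also carries a pyridin-2-yl-bearing aromatic group on the sulfonyl sulfur and gives 0.9, so the change does not appear to pull the maximal response out of the band seen so far.

For compound 4 the expected step is a number 0.050 higher from compound 2 to compound 4 (within the scatter), no more than the scatter, in either direction. Compound 4 is estimated at 0.85 with a range from 0.7 to 1.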

Compound 4, intrinsic activity: the largest response reached, as a fraction of the reference agonist's: 0.9
Beside the measured number, compound 4's estimate is 0.050 below it; the range from low to high includes it.
By their numbers in this assay, from the lowest: compounds 1, 2, 3 and 4 (each within the scatter of the next).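

Replacing 3-iodobenzyl with 5-(pyridin-2-yl)thiophen-2-yl on a sulfonyl sulfur gives in this assay a number 0.10 higher from compound 2 to compound 4 (within the scatter) and so leaves the maximal response in the same narrow band, even with a two-ring heteroaromatic group at this place. Compound 3 gives 0.9 and compound 4 gives 0.9 at the digits printed, so the two pyridin-2-yl-bearing groups read alike here. Nothing available explains this result.

Still open, on these data alone, is whether a primary amine, a carboxylic acid or a short alkyl chain on the sulfonyl sulfur would take the maximal response out of this band. Also open, as far as these compounds go, is whether any group at this place can separate from the others by more than the scatter.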